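A few compounds are considered here, and "the series" means these few. Any claim that something is new, unique, unknown or untested is made for them only; others in the source may bear on it.

Three compounds built on a shared core, each carrying a different group on a triple-bonded carbon, have been tested in a functional assay on L1210 cells (Mus musculus); on this read-out lower numbers stand for stronger inhibition and higher numbers for weaker inhibition. Compound 1, `CC(C)(C)C#Cc1cn([C@H]2C[C@H](O)[C@@H](CO)O2)c(=O)[nH]c1=O`, gives 287 ug/mL in this assay. Compound 2, `CCCCC#Cc1cn([C@H]2C[C@H](O)[C@@H](CO)O2)c(=O)[nH]c1=O`, gives 1000 ug/mL. Compound 3, `COCC#Cc1cn([C@H]2C[C@H](O)[C@@H](CO)O2)c(=O)[nH]c1=O`, gives 254 ug/mL. On these numbers compound 3 stands lowest of the three: its gap to compound 1 lies within the scatter, while the step of a 3.9-fold lower number from compound 2 to compound 3 (0.60 log units; beyond the scatter) lies beyond it.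

Compound 4, `CCCC/C=C\c1cn([C@H]2C[C@H](O)[C@@H](CO)O2)c(=O)[nH]c1=O`, has not yet been measured. It differs from compound 3 in one place: hex-1-en-1-yl in place of 3-methoxyprop-1-yn-1-yl on an aromatic carbon. Going by the values given here, no measured step exchanges a triple bond for a double bond, so the steps that bear on this change do so only indirectly. The step of a 3.9-fold lower number from compound 2 to compound 3 (0.60 log units; beyond the scatter) was modest, as was the step of a 3.5-fold higher number from compound 1 to compound 2 (0.54 log units; beyond the scatter). From the compounds shown here alone, the hex-1-en-1-yl group of compound 4 has no hydrogen-bond acceptor and resembles the butyl-bearing chain of compound 2, whose 1000 ug/mL is the highest number seen, so a modest rise from compound 3 is expected, with a wide range since the double bond itself is untested. Compound 4 is therefore estimated at 650 ug/mL, between 250 ug/mL and 1800 ug/mL. This corresponds to an expected step of a 2.6-fold higher number from compound 3 to compound 4 (0.41 log units; beyond the scatter).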

Compound 4, concentration for 50% inhibition: 361 ug/mL
For compound 4 the middle estimate is 1.8-fold (0.26 log units) above the measured one; the measured number falls inside the stated range.
By their numbers in this assay, from the lowest: compounds 3, 1 and 4 (each within the scatter of the next); then compound 2.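

In this assay, going by these compounds alone, exchanging hex-1-yn-1-yl for hex-1-en-1-yl on the same aromatic carbon gives a 2.8-fold lower number from compound 2 to compound 4 (0.44 log units; beyond the scatter), the only step here that alters the bond in the chain while leaving the chain otherwise unchanged; the high number of compound 2 is therefore not tied to the hexyl-length chain alone, but also depends on the triple bond in this one pair. The two other new steps, a 1.4-fold higher number from compound 3 to compound 4 (0.15 log units; within the scatter) and a 1.3-fold higher number from compound 1 to compound 4 (0.10 log units; within the scatter), show that hex-1-en-1-yl, with no hydrogen-bond acceptor, cannot be told apart on this read-out from either 3-methoxyprop-1-yn-1-yl, which has one, or 3,3-dimethylbut-1-yn-1-yl, which has none. Nothing in hand explains why the double bond and the triple bond differ in this pair.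

A single pair cannot show whether the same exchange holds on other chains, such as 3-methoxyprop-1-en-1-yl in place of 3-methoxyprop-1-yn-1-yl. The compounds shown also leave open how a fully saturated hexyl chain, or the other double-bond geometry of hex-1-en-1-yl, would read at this aromatic carbon.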